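Chain length and methoxy substitution across the shared core

The source may hold more compounds than are shown below. What is called first, only, known or untested is meant among the compounds shown, and "the series" means these compounds.

Compound 1 `CCOC(=O)N1N=C(c2ccccc2)CC1c1cc(OC)c(OC)c(OC)c1` carries an ethyl carbamate on the shared core. In a functional assay on HepG2 cells (Homo sapiens) for antiproliferative activity, read by MTT assay, with a stated time of 48 h (a lower number here means a stronger inhibitor of growth, a higher number a weaker inhibitor of growth), compound 1 gives 5950 nM. Compound 2 `CCCOC(=O)N1N=C(c2ccccc2)CC1c1cc(OC)c(OC)c(OC)c1` differs by methyl in place of hydrogen on a saturated chain carbon, two bonds along the chain from an oxygen next to a carbonyl group. Compound 2 reaches only a limit in this assay, > 10000 nM, as noted in the limit of > 10000 nM in this assay, at which 1 of the 3 values shown sits. The step of an at least 1.6-fold higher number from compound 1 to compound 2 (0.22 log units; that floor lies within the scatter) therefore has a floor only.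

Compound 3 `CCOC(=O)N1N=C(c2ccc(OC)cc2)CC1c1cc(OC)c(OC)c(OC)c1` differs from compound 1 by methoxy in place of hydrogen on an aromatic carbon, and in this assay compound 3 gives 9400 nM, a step of a 1.6-fold higher number from compound 1 to compound 3 (0.20 log units; within the scatter).

Compound 4 `CCCOC(=O)N1N=C(c2ccc(OC)cc2)CC1c1cc(OC)c(OC)c(OC)c1` is not yet measured. It differs from compound 3 by methyl in place of hydrogen on a saturated chain carbon, two bonds along the chain from an oxygen next to a carbonyl group, the same change as that from compound 1 to compound 2, placed on the same chain position; the two cores differ by methoxy in place of hydrogen on an aromatic carbon.

Going by the values given here, for compound 4 a step of a 1.4-fold higher number from compound 3 to compound 4 (0.14 log units; within the scatter) is expected in this assay, resting on the only matched pair, where an at least 1.6-fold higher number from compound 1 to compound 2 (0.22 log units; that floor lies within the scatter) was seen from compound 1 to compound 2. Compound 4 is accordingly estimated at 13000 nM, with a range from 6000 nM to 28000 nM, and a limit rather than a number is considered likely.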

Compound 4, concentration for 50% growth inhibition: > 10000 nM
Compound 4 was reported as a limit; the forecaster's own chance of this, stated with the estimate: 60%; the middle value is on the limit's open side.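

In this assay the new step, an at least 1.0-fold higher number from compound 3 to compound 4 (0.02 log units; that floor lies within the scatter), rests on a limit and gives a floor only. Set beside the earlier step, the change from ethyl to propyl leaves two floors on two cores, and neither gives a size: the same change on two cores in this assay, an at least 1.6-fold higher number (0.22 log units; that floor lies within the scatter) from compound 1 to compound 2 and an at least 1.0-fold higher number (0.02 log units; that floor lies within the scatter) from compound 3 to compound 4; the limit leaves it open whether they differ The propyl carbamates compound 2 and compound 4 both stand as limits, which does not show whether the change carries over from one core to the other with the same size, and the step between those two limits cannot be read.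

The compounds shown leave open what a shorter chain such as a methyl carbamate, or a longer chain such as a butyl carbamate, would give on either core. Also open, as far as these compounds go, is how an amine or a carboxylic acid in place of the added methoxy would read in this assay.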